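Working notes on compounds 1 to 3: one ring swap

The source may report more compounds than this note shows. Statements on the series, on what has been measured and on what is new or still open speak of the compounds shown alone.

Within the data shown here, compound 1 `N#Cc1ccc(N2CCCc3c(-c4cccnc4)cccc32)cc1C(F)(F)F` is the only member with a number in an ADME assay on L02 cells (Homo sapiens) for antiproliferative activity, read by CCK-8 assay, with a stated time of 6 days; on this read-out lower numbers stand for stronger inhibition and higher numbers for weaker inhibition: compound 1 gives 10500 nM. Going by these compounds, compound 2 `CCN(c1ccc(C#N)c(Cl)c1)c1cc(-c2ccoc2)ccc1C` gives "not determined" (no result reported) in this assay, so where compound 2 stands on this read-out is unknown. Compound 3 `CCN(c1ccc(C#N)c(Cl)c1)c1cc(-c2ccnn2C)ccc1C` differs from compound 2 by 1-methyl-1H-pyrazol-5-yl in place of furan-3-yl on an aromatic carbon. Among the measured compounds shown here, no measured pair differing in one place is available, so the size of this step is unknown; nothing beyond the usual scatter in this assay is expected in either direction, and compound 1 is the only anchor. Compound 3 is expected to give 10000 nM in this assay, within a range from 2500 nM to 40000 nM.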

Compound 3, half-maximal inhibitory concentration: 6230 nM
Compound 3: the middle estimate sits 1.6-fold (0.21 log units) above what was measured; the range from low to high includes it.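

In this assay no step can be read between compound 2 and compound 3. The compounds shown leave open what replacing furan-3-yl with 1-methyl-1H-pyrazol-5-yl does on this read-out. No evidence bears on the result.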